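Bromine-bearing bicyclic core: from isopropyl toward tert-butyl

A few compounds are considered here, and "the series" means these few. Any claim that something is new, unique, unknown or untested is made for them only; others in the source may bear on it.

Compound 1 `CC[C@H](C)n1c(=O)[nH]c2ncc(Br)nc21` carries a sec-butyl group on the shared core; in an ADME assay on microsomes from liver (Rattus norvegicus), read by LC-MS, with a stated time of 90 min (a lower number here means that the liver removes a smaller share, a higher number that the liver removes a larger share of the compound in one pass), compound 1 gives 0.3. Compound 2 `CC(C)n1c(=O)[nH]c2ncc(Br)nc21` carries an isopropyl group in the same place, and in this assay compound 2 gives "not determined" (no result reported), so no number stands for it. Compound 3 `CC(C)(C)n1c(=O)[nH]c2ncc(Br)nc21` differs from compound 2 by methyl in place of hydrogen on a saturated chain carbon bound to an aromatic nitrogen and two saturated chain carbons. Among the measured compounds shown here, with no measured step to lean on, only a small shift in this assay, if any, is expected, and the estimate for compound 3 in this assay is 0.3, between 0.1 and 0.55, because compound 1 gives 0.3 as a close relative.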

Compound 3, hepatic extraction ratio: 0.3
Compound 3: the middle estimate sits on the measured number at the digits printed; the range from low to high includes it.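

In this assay, among the compounds shown here, there is no change at the digits printed from compound 1 to compound 3 (within the scatter), the first measured step at this position: one branched group can replace another on the aromatic nitrogen with no visible effect on the share the liver removes. The step from compound 2 to compound 3 cannot be read, as compound 2 has no number. No measurement shown here explains this result. Still open, going by these compounds, is how a straight group such as methyl, a longer chain, an amine or a carboxylic acid would behave at this place.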